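The source may report more compounds than this note shows. Statements on the series, on what has been measured and on what is new or still open speak of the compounds shown alone.

Measured compounds, with their results in an ADME assay on the whole organism (Rattus norvegicus), at a dose of 2 mg/kg by the oral route; a lower number here means less compound in the circulation, a higher number more compound in the circulation at the dose given:
Compound 1 `COc1cc(OCc2cccc(-c3ccc(C#N)cc3)c2)c2cc(-c3cn4nc(OC)sc4n3)oc2c1`: 610 ng.h/mL
Compound 2 `COc1cc(OCc2cccc(-c3ccc(C#N)cn3)c2)c2cc(-c3cn4nc(OC)sc4n3)oc2c1`: 464 ng.h/mL
Compound 3 `COc1cc(OCc2cccc(-c3ccc(OC)nc3)c2)c2cc(-c3cn4nc(OC)sc4n3)oc2c1`: 1800 ng.h/mL

Compound 3 stands highest of the three, a 3.0-fold higher number from compound 1 to compound 3 (0.47 log units; beyond the scatter) and a 3.9-fold higher number from compound 2 to compound 3 (0.59 log units; beyond the scatter), both beyond the scatter; compounds 1 and 2 sit within the scatter of each other, a 1.3-fold lower number from compound 1 to compound 2 (0.12 log units; within the scatter).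

Compound 4 `COc1cc(OCc2cccc(OCc3ccccc3)c2)c2cc(-c3cn4nc(OC)sc4n3)oc2c1` is not yet measured. Its change from compound 3 is benzyloxy in place of 6-methoxypyridin-3-yl on an aromatic carbon. For the measured compounds named here, the two steps into compound 3 bear on it only in that the leaving group gave the highest number among the groups tried at this position; no measured step brings in a benzyloxy group, so the entering group has no precedent in this set. A modest fall from compound 3 is expected, a 2.3-fold lower number from compound 3 to compound 4 (0.35 log units; beyond the scatter), with wide uncertainty. For compound 4 the estimate in this assay is 800 ng.h/mL, between 250 ng.h/mL and 2500 ng.h/mL.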

Compound 4, area under the concentration-time curve: 339 ng.h/mL
Beside the measured number, compound 4's estimate is 2.4-fold (0.37 log units) above it; low and high end bracket the measured number.
By their numbers in this assay, from the lowest: compounds 4, 2 and 1 (each within the scatter of the next); then compound 3.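

In this assay, the 8 heavy atoms shared by the two groups do not keep the number high: benzyloxy in place of 6-methoxypyridin-3-yl gives a clear fall (a 5.3-fold lower number from compound 3 to compound 4 (0.73 log units; beyond the scatter)). Compound 4 lies within the scatter of both nitrile-bearing compounds (a 1.4-fold lower number from compound 2 to compound 4 (0.14 log units; within the scatter); a 1.8-fold lower number from compound 1 to compound 4 (0.26 log units; within the scatter)), so among these four groups only 6-methoxypyridin-3-yl stands apart. No measurement on hand accounts for these differences.

Open, from the compounds shown here alone, is whether a basic amine or a carboxylic acid at this position would keep the number of compound 3 or fall with the others.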